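Swapping the ketone's aryl group for a thiophene

The source may hold more compounds than are shown below. What is called first, only, known or untested is meant among the compounds shown, and "the series" means these compounds.

Measured in an assay on isolated protein for inhibition of histone deacetylase HD1B (Zea mays); a higher number here means a weaker inhibitor, a lower number a stronger inhibitor:
compound 1 `Cn1cc(/C=C/C(=O)c2ccc(Cl)cc2)cc1/C=C/C(=O)NO`: 29400 nM
compound 2 `Cn1cc(/C=C/C(=O)c2ccc(F)cc2)cc1/C=C/C(=O)NO`: 24900 nM
compound 3 `Cc1cccc(C(=O)/C=C/c2cc(/C=C/C(=O)NO)n(C)c2)c1`: 2500 nM

Compound 3 stands lowest of the three, so it is the strongest inhibitor here. Exchanging the halogen on the aryl ring changed little, a 1.2-fold lower number from compound 1 to compound 2 (0.07 log units; within the scatter), whereas exchanging the whole aryl group moved the number a long way: a 12-fold lower number from compound 1 to compound 3 (1.07 log units; beyond the scatter) and a 10-fold lower number from compound 2 to compound 3 (1.00 log units; beyond the scatter). Compound 4 `Cn1cc(/C=C/C(=O)c2ccsc2)cc1/C=C/C(=O)NO` is the next step, with thiophen-3-yl in place of 3-methylphenyl on a carbonyl carbon. For the measured compounds named here, no measured pair exchanges this aryl group for a five-membered ring, so the earlier steps only show that this position matters greatly and that the three-methylphenyl was the best of the tried groups. Compound 4 is therefore expected to give a weaker number, 8000 nM, within 2000 nM to 30000 nM, a step of a 3.2-fold higher number from compound 3 to compound 4 (0.51 log units; beyond the scatter).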

Compound 4, half-maximal inhibitory concentration: 22600 nM
For compound 4 the middle estimate is 2.8-fold (0.45 log units) below the measured one; the range from low to high includes it.
By their numbers in this assay, from the lowest: compound 3; then compounds 4, 2 and 1 (each within the scatter of the next).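

In this assay, the thiophen-3-yl group does not keep the advantage of the 3-methylphenyl group: a 9.0-fold higher number from compound 3 to compound 4 (0.96 log units; beyond the scatter). Instead, it matches the two halogen-bearing aryl groups, with a 1.1-fold lower number from compound 2 to compound 4 (0.04 log units; within the scatter) and a 1.3-fold lower number from compound 1 to compound 4 (0.11 log units; within the scatter), so among these four groups only 3-methylphenyl stands apart on this carbonyl carbon. Nothing available here explains why that group differs from the others.

The compounds shown leave open whether the methyl itself matters, which plain phenyl could test. They also leave open whether 3-ethylphenyl or 3-methoxyphenyl would match compound 3.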